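Swapping an alkyne for a thiophene on a bicyclic nucleoside

The source may hold more compounds than are shown below. What is called first, only, known or untested is meant among the compounds shown, and "the series" means these compounds.

Measured compounds:
compound 1 `CC#CC1=C(N)[C@@]2(OS1(=O)=O)[C@@H](CO[Si](C)(C)C(C)(C)C)O[C@@H](n1cc(C)c(=O)n(C)c1=O)[C@@H]2O[Si](C)(C)C(C)(C)C` — 3300 nM
compound 2 `CNC1=C(C)S(=O)(=O)O[C@@]12[C@@H](CO[Si](C)(C)C(C)(C)C)O[C@@H](n1cc(C)c(=O)n(C)c1=O)[C@@H]2O[Si](C)(C)C(C)(C)C` — > 250000 nM

Among the compounds with values here, in a functional assay on MT4 cells (Homo sapiens) for cytotoxicity (a higher number here means that more compound is tolerated, a lower number that less compound is tolerated), compound 1 gives 3300 nM, the only plain number among the two results. For compound 2 this assay gives only a limit, > 250000 nM, so it is the limit of > 250000 nM in this assay, at which 1 of the 2 values shown sits, and no number. Within the data shown here, compound 2 differs from compound 1 in more than one place, so the two results show only that compound 2 is tolerated at far higher concentration.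

Compound 3 `Cc1cn([C@@H]2O[C@H](CO[Si](C)(C)C(C)(C)C)[C@@]3(OS(=O)(=O)C(c4ccsc4)=C3N)[C@H]2O[Si](C)(C)C(C)(C)C)c(=O)n(C)c1=O` has not yet been tested in this assay. It differs from compound 1 by thiophen-3-yl in place of prop-1-yn-1-yl on a double-bonded ring carbon. Among the measured compounds shown here, no measured pair isolates such a change, so the size of the step is open; the expectation is a modest rise in tolerated concentration, a 3.0-fold higher number from compound 1 to compound 3 (0.48 log units; beyond the scatter), though a result within the scatter is plausible. Compound 3 is estimated at 10000 nM, in the range 2000 nM to 100000 nM.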

Compound 3, half-maximal cytotoxic concentration: 3900 nM
For compound 3 the middle estimate is 2.6-fold (0.41 log units) above the measured one; low and high end bracket the measured number.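

Read in this assay the change gives a 1.2-fold higher number from compound 1 to compound 3 (0.07 log units; within the scatter) and so offers the first comparison here that isolates one place on the shared core. On the double-bonded ring carbon, next to the ring sulfur, thiophen-3-yl with its 5 heavy atoms and aromatic ring reads the same as prop-1-yn-1-yl with its 3 heavy atoms and triple bond, so this swap leaves the tolerated concentration within the scatter. Nothing measured here explains why these two groups read alike.

Compound 2 differs from compound 1 and from compound 3 in more than one place, so steps to it cannot be read. Open too is how a phenyl ring, a carboxylic acid or a longer chain on the same ring carbon would read in this assay, as none of these groups is among the compounds shown.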